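Cyclizing the diethylamino group of a weak urea inhibitor

The source may hold more compounds than are shown below. What is called first, only, known or untested is meant among the compounds shown, and "the series" means these compounds.

The study concerns acylureas built on a shared core carrying two isopropyl groups, tested in an assay on microsomes from intestine for inhibition of acyl-CoA:cholesterol acyltransferase (Oryctolagus cuniculus); a lower number here means a stronger inhibitor, a higher number a weaker inhibitor. Compound 1 `CC(C)c1cccc(C(C)C)c1NC(=O)NC(=O)N(c1ccccc1)c1ccccc1`, which bears a diphenylamino group on the carbonyl carbon, gives 340 nM in this assay. Compound 2 `CCN(CC)C(=O)NC(=O)Nc1c(C(C)C)cccc1C(C)C` carries a diethylamino group at that position instead. In this assay compound 2 is reported only as a limit, > 5000 nM, so its exact potency is not known. One of the two values shown therefore sits at the limit of > 5000 nM in this assay, at which 1 of the 2 values shown sits, and the two compounds differ at least widely in this assay.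

Compound 3 `CC(C)c1cccc(C(C)C)c1NC(=O)NC(=O)N1CCCC1` is not yet measured. It differs from compound 2 by pyrrolidin-1-yl in place of diethylamino on a carbonyl carbon, a cyclic amine replacing the open-chain one while leaving the rest of the molecule untouched. Among the measured compounds shown here, since compound 2 stands only at a limit, no measured step to rest on exists; the change is expected to be small, with no step beyond the scatter, and compound 3 is estimated to lie at 5000 nM, between 1500 nM and 20000 nM. This corresponds to an expected step of a number no higher from compound 2 to compound 3 (the limit leaves the size open).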

Compound 3, half-maximal inhibitory concentration: > 5000 nM
Compound 3 ended at the assay's limit (the forecaster's own chance of this, stated with the estimate: 60%); the middle value lies on the limit itself.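

In this assay compound 3 gives > 5000 nM, a limit of the assay. Compound 2 gives > 5000 nM, also a limit. Among the compounds shown here, no step between compound 2 and compound 3 can be read. The compounds shown leave open the actual potency of both compounds, and whether pyrrolidin-1-yl in place of diethylamino changes it at all.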